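Swapping a Fluorophenyl for a Methylfuranyl on the Shared Core

The compounds below may be only part of what the source reports. "The series", "measured", "known", "first", "only" and "open" are said of these compounds alone.

compound 1 `COc1nc(-c2nc3ccccc3n2C)cc(-c2ccc(Cl)cc2)c1C#N` — 145000 nM
compound 2 `COc1nc(-c2nc3ccccc3n2C)cc(-c2ccc(F)cc2)c1C#N` — 343000 nM
compound 3 `CCOc1nc(-c2nc3ccccc3n2C)cc(-c2ccc(F)cc2)c1C#N` — 362000 nM

Of the compounds shown here, three on one shared core have been measured in a functional assay on aorta (Rattus norvegicus, strain Wister); on this read-out higher numbers stand for weaker inhibition and lower numbers for stronger inhibition. Compound 3 gives the highest number of the three. Its gap to compound 2 lies within the scatter, so the two cannot be told apart, whereas compound 1 gives a lower number and that gap lies beyond the scatter.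

Compound 4 `CCOc1nc(-c2nc3ccccc3n2C)cc(-c2ccc(C)o2)c1C#N` differs from compound 3 in one place: 5-methylfuran-2-yl in place of 4-fluorophenyl on an aromatic carbon. Of the measured steps, only a 2.4-fold higher number from compound 1 to compound 2 (0.37 log units; beyond the scatter) touches the same aryl group, and there a single halogen swap gave a modest rise. The other step, a 1.1-fold higher number from compound 2 to compound 3 (0.02 log units; within the scatter), concerns the ethoxy group and does not bear on this change. Going by the values given here, exchanging the whole six-membered ring for 5-methylfuran-2-yl is a larger alteration than either, and no measured pair shows such a ring exchange, so the direction is open.

Given that the only comparable step, a 2.4-fold higher number from compound 1 to compound 2 (0.37 log units; beyond the scatter), was modest, compound 4 is expected to shift by a 1.2-fold lower number from compound 3 to compound 4 (0.08 log units; within the scatter), a step hardly beyond the scatter. Compound 4 is therefore estimated at 300000 nM, with a range from 100000 nM to 900000 nM.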

Compound 4, half-maximal inhibitory concentration: 336000 nM
The estimate for compound 4 lay 1.1-fold (0.05 log units) below the measured number; the measured number falls inside the stated range.
By their numbers in this assay, from the lowest: compound 1; then compounds 4, 2 and 3 (each within the scatter of the next).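

In this assay, the step from 4-fluorophenyl to 5-methylfuran-2-yl, on the aromatic carbon ortho to a cyano group and opposite the ring nitrogen, is a 1.1-fold lower number from compound 3 to compound 4 (0.03 log units; within the scatter), so compound 3 and compound 4 cannot be told apart. The earlier compounds had shown this position only with a six-membered aromatic ring of carbon only, where the halogen swap gave a 2.4-fold higher number from compound 1 to compound 2 (0.37 log units; beyond the scatter); compound 4 shows that a five-membered aromatic ring with one hetero atom, carrying a methyl group and counting one more hydrogen-bond acceptor, can stand here with no readable difference from the 4-fluorophenyl compound in the ethoxy series. No measurement of any property of these groups accompanies the result, so the data give no explanation for it.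

As far as these compounds go, whether a chloro group on the phenyl ring would give the same gap in the ethoxy series as it does in the methoxy series remains open, as does the part played by the methyl group on the furan ring. From the compounds shown here alone, it is also open whether an amine or a carboxylic acid on the aryl group at this position would separate from compound 3 in this assay, or leave the number within the scatter as compound 4 does.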